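This account rests on a few compounds, and the source may have more. Where it says the series, first, only, none or still open, it means among the compounds named here.

Working notes on the series, covering three compounds that share one core and differ in the length of the chain on it. In a functional assay on the whole organism (Tail) with Mus musculus as the target (on this read-out lower numbers stand for an effect already at smaller amounts and higher numbers for an effect only at larger amounts of compound), compound 1 (`CCCc1ccc(C2CCCN2C)cn1`) gives > 70 umol/kg; > 70 umol/kg (2 entries), and both entries are limits, not numbers. Compound 2 (`CCCCCc1ccc(C2CCCN2C)cn1`) gives > 50 umol/kg, which is also a limit. Among the compounds with values here, no single number is available for compound 2, so its position is known only as that limit, and no measured step exists to set a scale.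

Compound 3 (`CCCCc1ccc(C2CCCN2C)cn1`) has not yet been measured. It differs from compound 2 by hydrogen in place of methyl on a saturated chain carbon, four bonds along the chain from an aromatic carbon.

With only limits to go on, no direction can be drawn from the data, and a step beyond the usual scatter is not expected. The expected step that the limit leaves unreadable from compound 2 to compound 3 is therefore small. A report of only a limit is more likely than not for compound 3 in this assay. If a number is returned, the estimate for compound 3 is 60 umol/kg, with an expected range of 20 umol/kg to 150 umol/kg.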

Compound 3, dose for half-maximal effect: > 50 umol/kg
Compound 3 was reported as a limit; the forecaster's own chance of this, stated with the estimate: 60%; the middle value lies beyond the limit too.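

In this assay compound 3 gives > 50 umol/kg and this is a limit, not a number. No step can be read between compound 2 and compound 3, because both are reported only at the same limit: the limit of > 50 umol/kg in this assay, at which 2 of the 3 values shown sit.

The compounds shown leave open whether the length of the chain changes the effect in this assay at all, as none of them has a single number.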